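Exchanging the Ring-Nitrogen Group of Compound 3

The compounds below may be only part of what the source reports. "The series", "measured", "known", "first", "only" and "open" are said of these compounds alone.

Measured so far:
- Compound 1, `O=C(NCCNS(=O)(=O)c1ccc(-c2ccccc2Oc2ccc(O)c(O)c2)s1)Nc1cc(Cl)cc(Cl)c1`: 10400 nM
- Compound 2, `O=C(NCCNS(=O)(=O)c1ccc(-c2ccccc2O[C@H]2CC[C@H](O)CC2)s1)Nc1cc(Cl)cc(Cl)c1`: > 20000 nM
- Compound 3, `O=C(Nc1cccc([N+](=O)[O-])c1)N1CCN(S(=O)(=O)c2sccc2-c2ccccc2Oc2ccc(O)c(O)c2)CC1`: 4500 nM

In a functional assay on HL-60 cells (Homo sapiens) for inhibition, read by CCK-8 assay, with a stated time of 48 h (on this read-out higher numbers stand for weaker inhibition and lower numbers for stronger inhibition), compound 1 gives 10400 nM. Compound 2 reaches only the limit of this assay, > 20000 nM, and no number is known for it. The step of an at least 1.9-fold higher number from compound 1 to compound 2 (0.28 log units; that floor lies within the scatter) therefore has only a floor, and that floor lies within the scatter, as noted at the limit of > 20000 nM in this assay, at which 1 of the 3 values shown sits. Compound 3 gives 4500 nM, the lowest of the two numbers shown, with compound 1 nearest to it.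

Compound 4, `O=[N+]([O-])c1ccc(NC(=S)N2CCN(S(=O)(=O)c3sccc3-c3ccccc3Oc3ccc(O)c(O)c3)CC2)cc1`, is not yet measured. It differs from compound 3 in one place: a group of 12 heavy atoms (7 carbon, 2 nitrogen, 2 oxygen, 1 sulfur; one six-membered aromatic ring of carbon only) in place of a group of 12 heavy atoms (7 carbon, 2 nitrogen, 3 oxygen; one six-membered aromatic ring of carbon only), on an amine nitrogen in a ring. The group that enters has no common name; it is counted with one sulfur where the leaving (3-nitrophenyl)carbamoyl has a third oxygen, and it carries the same number of donors and acceptors.

Going by the values given here, no measured step touches this place. The only step shown, from compound 1 to compound 2, changes the group on the aromatic oxygen, not the ring nitrogen, so it gives no guidance here. With nothing to lean on, compound 4 is expected to sit close to compound 3, a step of no change at the digits printed from compound 3 to compound 4 (within the scatter) that stays within the scatter. Compound 4 is thus estimated at 4500 nM, between 1800 nM and 11000 nM.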

Compound 4, half-maximal inhibitory concentration: 5300 nM
Beside the measured number, compound 4's estimate is 1.2-fold (0.07 log units) below it, within the range that was stated.
By their numbers in this assay, from the lowest: compounds 3, 4 and 1 (each within the scatter of the next, the first and the last beyond it). At a limit, above all of these: compound 2.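

In this assay, going by these compounds alone, the first measured exchange on the amine nitrogen in the ring, where the entering group holds one sulfur in place of the third oxygen of (3-nitrophenyl)carbamoyl, gives a 1.2-fold higher number from compound 3 to compound 4 (0.07 log units; within the scatter) and nothing larger. The two groups match in heavy atoms, donors and acceptors, and for this one pair the position shows no difference that this assay can separate from scatter. Nothing measured here gives a reason for this result.

Going by these compounds, both groups carry one six-membered aromatic ring of carbon only, so it remains open how this ring nitrogen would read with a small acetyl group, a simple amine chain or a carboxylic acid in their place. Also open, on these data alone, is whether the same exchange would read alike on the core of compound 1.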